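Anilide ring substituent swap: methyl exchanged for chloro

A few compounds are considered here, and "the series" means these few. Any claim that something is new, unique, unknown or untested is made for them only; others in the source may bear on it.

Compound 2 `Cc1ccc(NC(=O)CSc2nnc(-c3ccoc3C)n2Cc2ccco2)cc1` holds the lower of the two numbers measured in a functional assay on CHO cells for antagonist activity at Orexin receptor type 2 (Homo sapiens), read by FLIPR and calcium flux; a lower number here means a stronger inhibitor, a higher number a weaker inhibitor: compound 2 gives 39.8 nM, while compound 1 `Cc1ccc(C)c(NC(=O)CSc2nnc(-c3ccoc3C)n2Cc2ccco2)c1` gives 398 nM. Among the measured compounds shown here, the only step measured so far is a 10-fold lower number from compound 1 to compound 2 (1.00 log units; beyond the scatter). Compound 3 `Cc1occc1-c1nnc(SCC(=O)Nc2ccc(Cl)cc2)n1Cc1ccco1` differs from compound 2 by chloro in place of methyl on an aromatic carbon, on an aromatic carbon of a six-membered aromatic ring of carbon only. The step from compound 1 to compound 2 concerns substituents on that same ring and shows that changes there can move the number, but it removes a methyl rather than exchanging one for chloro, so it sets no direction for the new step. For the measured compounds named here, no measured pair exchanges methyl for chloro. The step from compound 2 to compound 3 is therefore expected to be a 1.0-fold higher number from compound 2 to compound 3 (0.00 log units; within the scatter), within the scatter. Compound 3 is estimated at 40 nM in this assay, with a range of 15 nM to 120 nM.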

Compound 3, inhibition constant: 100 nM
For compound 3 the middle estimate is 2.5-fold (0.40 log units) below the measured one; the measured number falls inside the stated range.
By their numbers in this assay, from the lowest: compound 2; then compound 3; then compound 1.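

Methyl and chloro are not interchangeable on the aromatic carbon para to a large group: in this assay the exchange gives a 2.5-fold higher number from compound 2 to compound 3 (0.40 log units; beyond the scatter), although the count of heavy atoms, hydrogen-bond donors and acceptors and the net charge stay the same. The 4-chlorophenyl group in place of 2,5-dimethylphenyl still gives a 4.0-fold lower number from compound 1 to compound 3 (0.60 log units; beyond the scatter), so the order by number, from the lowest, runs 4-methylphenyl, 4-chlorophenyl, 2,5-dimethylphenyl. No supporting measurement is available to explain these steps.

On these data alone, whether a methoxy group, a trifluoromethyl group or an amine at this position would give a lower number than compound 2 remains open. Also open, as far as these compounds go, is whether the methyl-to-chloro step would keep its size on a ring carrying a second methyl, as in compound 1.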